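A few compounds are considered here, and "the series" means these few. Any claim that something is new, unique, unknown or untested is made for them only; others in the source may bear on it.

Compound 1 `CSc1ccc(NC(=O)Nc2cc(C)nc3ccccc23)cc1`: > 25000 nM, a limit of the assay
Compound 2 `CC(=O)c1ccc(NC(=O)Nc2cc(C)nc3ccccc23)cc1`: 22000 nM

Both compounds were tested in an ADME assay on BJ cells (Homo sapiens) for cytotoxicity, with a stated time of 72 h; on this read-out higher numbers stand for an effect only at larger amounts of compound and lower numbers for an effect already at smaller amounts. For the measured compounds named here, compound 2, at 22000 nM, gives the only actual number so far. The result for compound 1 is a limit, and it is the sole entry at the limit of > 25000 nM in this assay, at which 1 of the 2 values shown sits.

Compound 3 `Cc1cc(NC(=O)Nc2ccc(N(C)C)cc2)c2ccccc2n1` has not yet been measured in this assay. Its structure departs from that of compound 2 in one place: dimethylamino in place of acetyl on an aromatic carbon. In words, this is dimethylamino in place of acetyl on an aromatic carbon, para to a large group.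

Going by the values given here, only one measured step bears on this change. It is an at least 1.1-fold lower number from compound 1 to compound 2 (0.05 log units; that floor lies within the scatter), and it exchanges the group on the same aromatic carbon. With that single step as the guide, no change beyond the scatter is expected, and so no direction is favoured. The expected size of the change is a 1.1-fold lower number from compound 2 to compound 3 (0.04 log units; within the scatter). For compound 3 the estimate is 20000 nM, with an expected range of 9000 nM to 40000 nM.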

Compound 3, half-maximal effective concentration: > 25000 nM
Compound 3: only a limit was reported; the forecaster's own chance of this, stated with the estimate: 45%; at least 1.2-fold (0.09 log units) between middle value and limit.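

In this assay, the aromatic carbon para to a large group now carries a third group, and with dimethylamino there compound 3 gives only a limit of the assay. Dimethylamino in place of acetyl gives an at least 1.1-fold higher number from compound 2 to compound 3 (0.05 log units; that floor lies within the scatter), which is a floor rather than a size, and the step between the two compounds that gave limits cannot be read. So the exchange at this position has still produced no readable step beyond the scatter, and the limit has become the most common result for this small series: the limit of > 25000 nM in this assay, at which 2 of the 3 values shown sit.

The compounds shown leave open how far the true values lie beyond the limit, and so whether dimethylamino and methylsulfanyl really differ from acetyl at this position in their effect on these cells. They also leave open whether a carboxylic acid, a primary amine or a longer alkyl chain on the same aromatic carbon, or a change elsewhere on the shared core, would bring an effect clearly beyond the scatter at smaller amounts of compound.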